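This account rests on a few compounds, and the source may have more. Where it says the series, first, only, none or still open, it means among the compounds named here.

Measured so far in an ADME assay on HL-60 cells (Homo sapiens) for cytotoxicity, read by MTT assay, with a stated time of 3 days; on this read-out higher numbers stand for lower toxicity in this test and lower numbers for higher toxicity in this test:
compound 1 `Cc1cn([C@@H]2CC[C@H](CO)O2)c(=O)nc1N` gives 950000 nM.
compound 2 `Cc1cn([C@@H]2C[C@@H](O)[C@H](CO)O2)c(=O)nc1N` gives only a limit, > 2000000 nM.
compound 3 `Cc1cn([C@@H]2C[C@@H](O)[C@H](CO)O2)c(=O)nc1NO` gives 600000 nM.

Compound 2 stands at the edge of what this assay reports: its value is a limit and not a number, and among the three values shown it is the one that sits there (the limit of > 2000000 nM in this assay, at which 1 of the 3 values shown sits). Compound 4 `Cc1cn([C@@H]2C[C@@H](F)[C@H](CO)O2)c(=O)nc1N` differs from compound 2 by fluoro in place of hydroxy on a saturated ring carbon.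

The measured step that touches the same saturated ring carbon is an at least 2.1-fold higher number from compound 1 to compound 2 (0.32 log units; beyond the scatter): hydroxy in place of hydrogen there went with a higher number. The other step, an at least 3.3-fold lower number from compound 2 to compound 3 (0.52 log units; beyond the scatter), concerns a hydroxy on a nitrogen on an aromatic ring and bears on compound 4 only indirectly. Among the measured compounds shown here, no measured compound carries fluoro, so whether fluoro at this carbon behaves more like hydroxy or like hydrogen cannot be read from the series; a number between the two is the plain expectation, with a fair chance that this assay again reports only a limit.

Compound 4 is therefore expected at about 1500000 nM, within 500000 nM to 4000000 nM. This estimate means a step of an at least 1.3-fold lower number from compound 2 to compound 4 (0.12 log units; that floor lies within the scatter) in this assay, expected to be small.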

Compound 4, half-maximal cytotoxic concentration: 1650000 nM
For compound 4 the middle estimate is 1.1-fold (0.04 log units) below the measured one; measured number inside the range.
By their numbers in this assay, from the lowest: compounds 3, 1 and 4 (each within the scatter of the next, the first and the last beyond it). At a limit, above all of these: compound 2.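

In this assay, among the compounds shown here, fluoro gives the first number for a group other than hydrogen or hydroxy on this saturated ring carbon, and the step of a 1.7-fold higher number from compound 1 to compound 4 (0.24 log units; within the scatter) does not separate fluoro from hydrogen. Against hydroxy, the step is an at least 1.2-fold lower number from compound 2 to compound 4 (0.08 log units; that floor lies within the scatter), so only its floor is known, and that floor does not establish a real change on replacing hydroxy with fluoro. Compound 2 gives only a limit, > 2000000 nM, and not a number: the limit of > 2000000 nM in this assay, at which 1 of the 4 values shown sits.

From the compounds shown here alone, how far hydroxy really stands from fluoro and hydrogen at this carbon remains open, so the series does not show whether hydroxy differs from both groups. Also open, going by these compounds, are the readings for an amine or a methoxy group on this carbon, and whether fluoro here would change the step seen with hydroxy on the nitrogen.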